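The source may report more compounds than this note shows. Statements on the series, on what has been measured and on what is new or still open speak of the compounds shown alone.

Measured so far in an assay on isolated protein for inhibition of protein kinase C theta type (Homo sapiens), read by HTRF; a lower number here means a stronger inhibitor, a higher number a weaker inhibitor:
- compound 1 `CO[C@@H]1[C@@H](O)[C@@H](O)[C@H]2O[C@]1(C)n1c3ccccc3c3c4c(c5c6ccccc6n2c5c31)C(=O)NC4`: 1010 nM
- compound 2 `CO[C@@H]1[C@H](N)C[C@H]2O[C@]1(C)n1c3ccccc3c3c4c(c5c6ccccc6n2c5c31)C(=O)NC4=O`: 36 nM
- compound 3 `COC(=O)[C@@]1(OC)C[C@H]2O[C@]1(C)n1c3ccccc3c3c4c(c5c6ccccc6n2c5c31)C(=O)NC4`: 520 nM

Compound 3 sits second highest of the three numbers in this assay. Against compound 1 the two values lie within the scatter, so no order between them is claimed; compound 2 stands well lower, beyond the scatter.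

Compound 4 `CN[C@]1(C(=O)OC)C[C@H]2O[C@]1(C)n1c3ccccc3c3c4c(c5c6ccccc6n2c5c31)C(=O)NC4` is the next step: methylamino in place of methoxy on a saturated ring carbon. Going by the values given here, no pair of measured compounds separated by this single change is at hand, so the expected step rests on the shared core alone. Among the compounds with values here, compound 2, the only member bearing a nitrogen substituent on that ring, gives 36 nM, but it differs from compound 3 in several places.

For compound 4 the step is expected to be a 1.7-fold lower number from compound 3 to compound 4 (0.24 log units; within the scatter) and to be modest at most. The estimate for compound 4 is 300 nM, within 90 nM to 1000 nM.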

Compound 4, half-maximal inhibitory concentration: > 2500 nM
Compound 4 ended at the assay's limit; the forecaster's own chance of this, stated with the estimate: 3%; middle value at least 8.3-fold (0.92 log units) away from the limit.
By their numbers in this assay, from the lowest: compound 2; then compounds 3 and 1 (each within the scatter of the next). At a limit, above all of these: compound 4.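

In this assay compound 4 gives > 2500 nM, a limit of the assay and not a number. Methylamino in place of methoxy on this saturated ring carbon gives an at least 4.8-fold higher number from compound 3 to compound 4 (0.68 log units; beyond the scatter). Going by these compounds alone, this is the only single-place change read, and it shows that this position is sensitive even to an exchange of equal heavy-atom count, which adds one hydrogen-bond donor.

On these data alone, the true size of the step remains open, since only its lower bound can be read. Also open, as far as these compounds go, is whether a primary amine, a hydroxyl or a dimethylamino group on this carbon would read like methoxy or like methylamino.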